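The compounds below may be only part of what the source reports. "The series", "measured", "known", "first", "only" and "open" are said of these compounds alone.

Compounds with measurements:

Compound 1 `NC[C@@H]1CCN(c2cc3c(cc2F)c(=O)c(C(=O)O)cn3Cc2nc(-c3ccncc3)no2)C1`. In an assay on isolated protein for inhibition of DNA topoisomerase 1 (Homo sapiens), with a stated time of 15 min (a lower number here means a stronger inhibitor, a higher number a weaker inhibitor), compound 1 reports only a limit, > 200000 nM.
Compound 2 `O=C(O)c1cn(Cc2ccc(-c3ccccc3)cc2)c2cc(NC[C@@H]3CCNC3)c(F)cc2c1=O`. In this assay compound 2 gives 104000 nM.
Compound 3 `O=C(O)c1cn(Cc2ccc(-n3cccn3)cc2)c2cc(NC[C@@H]3CCNC3)c(F)cc2c1=O`. In this assay compound 3 gives 200000 nM.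

Compound 3 holds the higher of the two numbers that were obtained. Going by the values given here, its nearest neighbour is compound 2, and the single measured step, a 1.9-fold higher number from compound 2 to compound 3 (0.28 log units; within the scatter), lies within the scatter, so the two cannot be ordered. The third value, that of compound 1, is a limit and not a number, as stated by the limit of > 200000 nM in this assay, at which 1 of the 3 values shown sits.

Compound 4 `NC[C@@H]1CCN(c2cc3c(cc2F)c(=O)c(C(=O)O)cn3Cc2ccc(-n3cccn3)cc2)C1` differs from compound 3 in one place: 3-(aminomethyl)pyrrolidin-1-yl in place of ((pyrrolidin-3-yl)methyl)amino on an aromatic carbon. The group that enters is the same one that compound 1 carries at that position. No measured step of this kind exists among these compounds; the only step, a 1.9-fold higher number from compound 2 to compound 3 (0.28 log units; within the scatter), changes a different part of the molecule and is within the scatter, so it gives no guidance on this change. The limit of compound 1, (the limit of > 200000 nM in this assay, at which 1 of the 3 values shown sits), is the only pointer, and it sits at the top of the measurable range. Compound 4 is therefore expected to give a number no lower than compound 3 and quite possibly only a limit. The estimated step is a 1.3-fold higher number from compound 3 to compound 4 (0.10 log units; within the scatter), upward. Compound 4 is estimated at 250000 nM, with a range from 100000 nM to 600000 nM.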

Compound 4, half-maximal inhibitory concentration: 91600 nM
For compound 4 the middle estimate is 2.7-fold (0.44 log units) above the measured one, and the stated range ends above it.
By their numbers in this assay, from the lowest: compounds 4, 2 and 3 (each within the scatter of the next, the first and the last beyond it).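

With compound 4, the position on the aromatic carbon ortho to a fluoro group gets its first readable step in this assay: exchanging ((pyrrolidin-3-yl)methyl)amino for 3-(aminomethyl)pyrrolidin-1-yl gives a 2.2-fold lower number from compound 3 to compound 4 (0.34 log units; beyond the scatter), a modest change from two groups with the same heavy atoms, the entering group counting 1 hydrogen-bond donor against 2. The same 3-(aminomethyl)pyrrolidin-1-yl group also stands in compound 1, and with 4-(1H-pyrazol-1-yl)phenyl in place of 3-(pyridin-4-yl)-1,2,4-oxadiazol-5-yl on the saturated chain carbon the result is an at least 2.1-fold lower number from compound 1 to compound 4 (0.33 log units; beyond the scatter), so this group does not by itself hold a compound at the top of the range. Compound 1 gives only a limit, so that second step has a lower bound and no exact size: the limit of > 200000 nM in this assay, at which 1 of the 4 values shown sits.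

The compounds shown leave open whether the first step would hold with phenyl in place of 1H-pyrazol-1-yl, as in compound 2, and whether it depends on the defined stereocentre. They also do not tell how a piperazin-1-yl or a 3-aminopyrrolidin-1-yl group on the same aromatic carbon would read in this assay.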